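This account rests on a few compounds, and the source may have more. Where it says the series, first, only, none or still open, it means among the compounds named here.

Compound 3 `Cn1c(CCc2ccccc2)nc2cc(Cl)c(Cl)cc21` gives 15300 nM in a functional assay on HepG2 cells (Homo sapiens) for cytotoxicity; a higher number here means that more compound is tolerated, a lower number that less compound is tolerated. Of the two numbers recorded it stands together with compound 2 `Cn1c(CCc2nccs2)nc2cc(Cl)c(Cl)cc21`, which gives 16000 nM in this assay, and the pair lie within scatter of each other, as a 1.0-fold lower number from compound 2 to compound 3 (0.02 log units; within the scatter). Compound 1 `Cn1c(CCC2CCCCC2)nc2cc(Cl)c(Cl)cc21` returns only a limit, > 500000 nM. The steps away from compound 1 are large: an at least 31-fold lower number from compound 1 to compound 2 (1.49 log units; beyond the scatter) and an at least 32-fold lower number from compound 1 to compound 3 (1.51 log units; beyond the scatter).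

Compound 4 `Cn1c(CCC2CCCO2)nc2cc(Cl)c(Cl)cc21` differs from compound 3 by oxolan-2-yl in place of phenyl on a saturated chain carbon, two bonds along the chain from an aromatic carbon. Among the measured compounds shown here, the measured step that bears most on this change is the one from compound 1 to compound 3, where a non-aromatic ring gave way to phenyl and the number fell, as an at least 32-fold lower number from compound 1 to compound 3 (1.51 log units; beyond the scatter); compound 4 reverses that direction, phenyl giving way to a non-aromatic ring, though the entering ring is five-membered and carries one oxygen. The step between compound 2 and compound 3 adds little guidance, since a 1.0-fold lower number from compound 2 to compound 3 (0.02 log units; within the scatter). An upward step is therefore expected for compound 4, a 3.9-fold higher number from compound 3 to compound 4 (0.59 log units; beyond the scatter), short of the full return to the limit seen for compound 1. Compound 4 is estimated at 60000 nM, within 15000 nM to 400000 nM.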

Compound 4, half-maximal cytotoxic concentration: 56000 nM
The estimate for compound 4 lay 1.1-fold (0.03 log units) above the measured number; the range from low to high includes it.
By their numbers in this assay, from the lowest: compounds 3 and 2 (each within the scatter of the next); then compound 4. At a limit, above all of these: compound 1.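

At this position, a non-aromatic ring need not reach the limit seen with cyclohexyl, and oxolan-2-yl gives a level distinct from both aromatic rings in this assay, with a 3.7-fold higher number from compound 3 to compound 4 (0.56 log units; beyond the scatter) and a 3.5-fold higher number from compound 2 to compound 4 (0.54 log units; beyond the scatter). The two non-aromatic rings also separate, with an at least 8.9-fold lower number from compound 1 to compound 4 (0.95 log units; beyond the scatter). Compound 1 stands at a limit, so this last step is a bound only: the limit of > 500000 nM in this assay, at which 1 of the 4 values shown sits.

The compounds shown do not separate the ring oxygen of oxolan-2-yl from its smaller ring size as the feature distinguishing compound 4 from compound 1; oxan-2-yl, a six-membered ring with one oxygen, would address that comparison. Also open, on these data alone, is where an amine such as piperidin-4-yl or a carboxylic acid would fall on the same saturated chain carbon.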